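From 2-chloroethoxy to phenyl on a carbonyl carbon

This account rests on a few compounds, and the source may have more. Where it says the series, first, only, none or still open, it means among the compounds named here.

Measured so far in a functional assay on K562 cells (Homo sapiens) for antiproliferative activity, read by MTT assay; a lower number here means a stronger inhibitor, a higher number a weaker inhibitor:
Compound 1 `CCCOC(=O)N1CCCc2cc(S(=O)(=O)N3CC(c4ccccc4)NC3=O)ccc21`: > 20000 nM, a limit of the assay and not a number
Compound 2 `O=C(OCCCl)N1CCCc2cc(S(=O)(=O)N3CC(c4ccccc4)NC3=O)ccc21`: 10600 nM

Within the data shown here, compound 2, at 10600 nM, holds the only actual number so far. Compound 3 `O=C(c1ccccc1)N1CCCc2cc(S(=O)(=O)N3CC(c4ccccc4)NC3=O)ccc21` has not yet been measured. It keeps the core of compound 2 and differs on a carbonyl carbon, with phenyl in place of 2-chloroethoxy on a carbonyl carbon. Among the measured compounds shown here, only one measured step bears on this, an at least 1.8-fold lower number from compound 1 to compound 2 (0.27 log units; that floor lies within the scatter). That step altered the very chain that compound 3 loses altogether, so it offers weak guidance and points in no direction. In this assay, no change beyond the scatter is therefore expected, though the uncertainty is wide. The expected size of the change is a 1.2-fold lower number from compound 2 to compound 3 (0.07 log units; within the scatter). For compound 3 the estimated value is 9000 nM, with an expected range of 3000 nM to 25000 nM.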

Compound 3, half-maximal inhibitory concentration: 1220 nM
Estimate against measurement, compound 3: 7.4-fold (0.87 log units) above; measured number outside the range, below it.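

In this assay, the group on this carbonyl carbon proves able to move the result well beyond the scatter: phenyl in place of 2-chloroethoxy gives an 8.7-fold lower number from compound 2 to compound 3 (0.94 log units; beyond the scatter), whereas the chloro-for-methyl change within the chain had shown no step beyond it. Phenyl in place of propoxy on the same carbon gives an at least 16-fold lower number from compound 1 to compound 3 (1.21 log units; beyond the scatter), and the size of that step is only a floor. The value of compound 1 is a limit of the assay and not a number: the limit of > 20000 nM in this assay, at which 1 of the 3 values shown sits.

The change from 2-chloroethoxy to phenyl removes the chain and its oxygen and brings in the ring all at once, so the compounds shown cannot say which of these matters. A benzyloxy group would keep both the oxygen and a phenyl ring, and a cyclohexyl group would show whether the ring must be aromatic.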